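Dichlorophenyl for difluorophenyl on the shared core

A few compounds are considered here, and "the series" means these few. Any claim that something is new, unique, unknown or untested is made for them only; others in the source may bear on it.

Among the compounds with values here, compound 2 `N=C(NCCCc1c[nH]cn1)NCCC(c1cc(F)cc(F)c1)c1ccccn1` stands highest of the two compounds measured so far: in a functional assay on muscle tissue for agonist activity at histamine H2 receptor (Cavia porcellus) (a higher number here means a more potent compound, by a factor of ten per unit of this negative logarithm, a lower number a less potent compound), compound 2 gives 7.91, while compound 1 `N=C(NCCCc1c[nH]cn1)NCCC(c1ccc(C(F)(F)F)cc1)c1ccccn1` gives 7.23. Within the data shown here, the one measured step, a number 0.68 log units higher from compound 1 to compound 2 (beyond the scatter), is the only result that bears on the change now at hand, and it does not repeat it. Compound 3 `N=C(NCCCc1c[nH]cn1)NCCC(c1ccc(Cl)c(Cl)c1)c1ccccn1` differs from compound 2 in a single place: 3,4-dichlorophenyl in place of 3,5-difluorophenyl on a saturated chain carbon bound to an aromatic carbon and a saturated chain carbon. Among the measured compounds shown here, no measured pair sets a dichlorophenyl against a difluorophenyl at that place, so the direction of this step is open; the known step says only that swapping the ring there can move the number modestly. A step of a number 0.31 log units lower from compound 2 to compound 3 (beyond the scatter) in this assay is therefore expected, small and within the scatter. Compound 3 is estimated at 7.6, with a range from 7 to 8.2.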

Compound 3, negative logarithm of the half-maximal effective concentration: 7.54
Beside the measured number, compound 3's estimate is 0.06 log units above it; measured number inside the range.
By their numbers in this assay, from the lowest: compound 1; then compound 3; then compound 2.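

In this assay the change to 3,4-dichlorophenyl gives a number 0.37 log units lower from compound 2 to compound 3 (beyond the scatter) and also a number 0.31 log units higher from compound 1 to compound 3 (beyond the scatter) so the three rings at this place now stand apart from one another by more than the scatter. Within the data shown here, the earlier pair showed only that one ring swap here could move the number, whereas this result shows that a ring with two halogens need not match the 3,5-difluorophenyl of compound 2 and can still stand above the 4-(trifluoromethyl)phenyl of compound 1. Nothing at hand gives a reason for this order.

Because halogen and ring pattern change together between compound 2 and compound 3, the compounds shown cannot separate the two, and a 3,5-dichlorophenyl group on this carbon would part them. They also leave open how an unsubstituted phenyl or a methoxyphenyl group would stand at this place.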